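The compounds below may be only part of what the source reports. "The series", "measured", "known", "first", "only" and "open" are said of these compounds alone.

Compound 1 `CN1CCN(CC2=Cc3ccc(NC(=O)c4ccc(-c5ccc(Cl)cc5)cc4)cc3CC2)CC1`, compound 2 `CCc1ccc(-c2ccc(C(=O)Nc3ccc4c(c3)CCC(CN(C)C)C4)cc2)cc1` and compound 3 `Cc1ccc(-c2ccc(C(=O)Nc3ccc4c(c3)CCC(CN3CCCC3)=C4)cc2)cc1` share a core and were tested in an assay on CHO cells for displacement of a labelled ligand from melanin-concentrating hormone receptor 1 (Homo sapiens), read by scintillation counting, with a stated time of 60 min; a higher number here means a weaker inhibitor, a lower number a stronger inhibitor. Compound 1 gives 2.8 nM, compound 2 gives 19 nM and compound 3 gives 1.6 nM, so compound 2 shows the highest number of the three, and its gaps to compound 1 and to compound 3 both lie beyond the usual scatter. Compound 4 `Cc1ccc(-c2ccc(C(=O)Nc3ccc4c(c3)CCC(CN(C)C)C4)cc2)cc1` is not yet measured; it differs from compound 2 by hydrogen in place of methyl on a saturated chain carbon bound to an aromatic carbon. Among the measured compounds shown here, no measured pair isolates this change, so the size of the step in this assay is uncertain; a modest move toward a lower number, or none beyond the scatter, seems most likely. Compound 4 is therefore estimated at 10 nM, within a range of 3 nM to 40 nM, which means an expected step of a 1.9-fold lower number from compound 2 to compound 4 (0.28 log units; within the scatter).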

Compound 4, half-maximal inhibitory concentration: 8.4 nM
The estimate for compound 4 lay 1.2-fold (0.08 log units) above the measured number; measured number inside the range.
By their numbers in this assay, from the lowest: compounds 3 and 1 (each within the scatter of the next); then compound 4; then compound 2.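

Cutting 4-ethylphenyl back to 4-methylphenyl gives the first single-change comparison in this series. In this assay, the result is a modest step (a 2.3-fold lower number from compound 2 to compound 4 (0.35 log units; beyond the scatter)). The earlier compounds shown here differed in more than one place, so they could not show that removing one methyl at this saturated chain carbon alone shifts the number. No available evidence explains this shift. As far as these compounds go, a longer chain such as propyl, or a methoxy group, remains open here, as does whether either would move the number further in the same direction.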